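A few compounds are considered here, and "the series" means these few. Any claim that something is new, unique, unknown or untested is made for them only; others in the source may bear on it.

Of the compounds shown here, three built on a shared core have been measured so far in an assay on HEK293 cells for displacement of a labelled ligand from adenosine receptor A2b (Homo sapiens), read by scintillation counting, with a stated time of 30 min, tested at 10 uM; on this read-out higher numbers stand for more inhibition at the one concentration tested (going by the name of the read-out) and lower numbers for less inhibition. Compound 1 `COc1cccc2cc(C(=O)NCC(=O)O)c(=O)oc12` gives 35%, compound 2 `COCCNC(=O)c1cc2cccc(OC)c2oc1=O` gives 18%, and compound 3 `COc1cccc2cc(C(=O)NCC(O)CO)c(=O)oc12` gives 25%. Compound 3 thus sits in the middle of the three numbers: its gap to compound 2 and its gap to compound 1 both lie within the usual scatter, so no order among them can be read with confidence. Among the compounds with values here, the one step that reaches beyond the scatter is a number 17 percentage points lower from compound 1 to compound 2 (beyond the scatter).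

Compound 4 `COc1cccc2cc(C(=O)NCCO)c(=O)oc12` differs from compound 3 by hydrogen in place of hydroxymethyl on a saturated chain carbon bound to an oxygen on a saturated carbon and a saturated chain carbon. All three measured steps change the same chain on the amide-type nitrogen, and two of them, a number 10 percentage points lower from compound 1 to compound 3 (within the scatter) and a number 7 percentage points higher from compound 2 to compound 3 (within the scatter), stayed within the scatter, while the third moved modestly. The change from compound 3 to compound 4 is smaller than any of those, so a step within the scatter is expected in this assay, if anything slightly downward toward the number of compound 2, giving an expected a number 3 percentage points lower from compound 3 to compound 4 (within the scatter). The estimate for compound 4 is therefore 22%, with a range from 10% to 34%.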

Compound 4, a percentage reported as inhibition, at one concentration (the size of the read-out at that concentration, not a potency): 7%
Compound 4: the middle estimate sits 15 percentage points above what was measured; the whole stated range lies above it.
By their numbers in this assay, from the lowest: compound 4; then compounds 2, 3 and 1 (each within the scatter of the next, the first and the last beyond it).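

Taking the hydroxymethyl off the 2,3-dihydroxypropyl chain to leave 2-hydroxyethyl is a small edit, yet in this assay it gives a number 18 percentage points lower from compound 3 to compound 4 (beyond the scatter) and so moves the number beyond the usual scatter, which no step involving compound 3 had done before. Hydrogen in place of methyl on the chain-end oxygen gives a number 11 percentage points lower from compound 2 to compound 4 (beyond the scatter) and hydroxymethyl in place of carboxy gives a number 28 percentage points lower from compound 1 to compound 4 (beyond the scatter) so that compound 4 now lies clearly below all three other compounds, and even the small differences at this chain end can register in this read-out. No measurement shown here offers an explanation for these steps.

As far as these compounds go, how an amine at the end of this chain would read stays open, and so does a longer chain ending in a hydroxyl. From the compounds shown here alone, every number here also comes from a single concentration, so potency itself remains unknown.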